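Ethynyl in place of chloro: what to expect

The source may report more compounds than this note shows. Statements on the series, on what has been measured and on what is new or still open speak of the compounds shown alone.

Measured so far in a functional assay on BMDM cells (Mus musculus, strain C57BL/6) for inhibition, with a stated time of 2 days; on this read-out lower numbers stand for stronger inhibition and higher numbers for weaker inhibition:
Compound 1 `Cc1cc(NC(=O)Cn2cc(-c3ccc(F)cc3)nn2)no1` gives > 30000 nM, which is a limit of the assay rather than a number.
Compound 2 `Cc1cc(NC(=O)Cn2cc(-c3ccc(C#N)cc3)nn2)no1` gives 9320 nM.
Compound 3 `Cc1cc(NC(=O)Cn2cc(-c3ccc(Cl)cc3)nn2)no1` gives 1910 nM.

Among the two numbers, compound 3 has the lowest, and so the strongest inhibition; compound 2 stands nearest, with a 4.9-fold lower number from compound 2 to compound 3 (0.69 log units; beyond the scatter). The other shown steps are an at least 3.2-fold lower number from compound 1 to compound 2 (0.50 log units; beyond the scatter) and an at least 15-fold lower number from compound 1 to compound 3 (1.19 log units; beyond the scatter), both starting from a limit (the limit of > 30000 nM in this assay, at which 1 of the 3 values shown sits).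

Compound 4 `C#Cc1ccc(-c2cn(CC(=O)Nc3cc(C)on3)nn2)cc1` is not yet measured. It differs from compound 3 by ethynyl in place of chloro on an aromatic carbon. For the measured compounds named here, no measured step involves an ethynyl group, so none bears directly on this change; the three steps only show that, at this position, the choice of group moves this assay by modest to large amounts, with chloro the best of the three tried. Compound 4 is therefore expected to land close to compound 3, with the step of a 1.3-fold higher number from compound 3 to compound 4 (0.12 log units; within the scatter) estimated as small and possibly toward weaker inhibition. Compound 4 is estimated at 2500 nM, within 800 nM to 8000 nM.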

Compound 4, half-maximal inhibitory concentration: > 30000 nM
Compound 4 ended at the assay's limit; the forecaster's own chance of this, stated with the estimate: 5%; at least 12-fold (1.07 log units) between middle value and limit.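

The result shows that this position does not treat every small group alike: in this assay, swapping chloro for ethynyl, one heavy atom for two carbons, costs a great deal, with an at least 15-fold higher number from compound 3 to compound 4 (1.19 log units; beyond the scatter). Cyano and ethynyl both carry a triple bond, yet they are not interchangeable here either, with an at least 3.2-fold higher number from compound 2 to compound 4 (0.50 log units; beyond the scatter). Compound 4 therefore sits with compound 1 at a limit of the assay rather than at a number, and the step between these two cannot be read: the limit of > 30000 nM in this assay, at which 2 of the 4 values shown sit.

Going by these compounds, how far compound 4 lies beyond that limit stays open, and the data cannot say what sets chloro apart from the other three groups. On these data alone, whether a bromo group, a methyl group or an amine at this position would match chloro, or improve on it, also remains unknown.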